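This account rests on a few compounds, and the source may have more. Where it says the series, first, only, none or still open, it means among the compounds named here.

Measured compounds in this series:

compound 1, `COc1cc(C(C)=O)ccc1OCCCN1CCC(C(c2ccc(Cl)cc2)c2ccc(Cl)cc2)CC1`, 2.51 nM
compound 2, `COc1cc(C(=O)O)ccc1OCCCN1CCC(C(c2ccc(F)cc2)c2ccc(F)cc2)CC1`, 79.4 nM

In a functional assay (aorta) with Oryctolagus cuniculus as the target (on this read-out higher numbers stand for weaker binding and lower numbers for tighter binding), compound 2 gives 79.4 nM, the higher of the two numbers shown. For the measured compounds named here, its nearest comparison is compound 1, which in this assay gives 2.51 nM, a gap far beyond the scatter; no single-point step between the two is available, so only their two values can be set side by side. The next compound, compound 3, `CN(CCCN1CCC(C(c2ccc(F)cc2)c2ccc(F)cc2)CC1)c1ccccc1`, is not yet measured. It differs from compound 2 as follows: methyl(phenyl)amino in place of 4-carboxy-2-methoxyphenoxy on a saturated chain carbon, three bonds along the chain from an amine nitrogen in a ring. Going by the values given here, with no step between measured compounds to lean on, the expected step of a 6.6-fold lower number from compound 2 to compound 3 (0.82 log units; beyond the scatter) is taken as a move toward a lower number, beyond the scatter, because compound 2 at 79.4 nM sits well above compound 1 in this series. Compound 3 is therefore estimated at 12 nM, with a likely range from 2.5 nM to 60 nM.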

Compound 3, dissociation constant: 2 nM
Estimate against measurement, compound 3: 6.0-fold (0.78 log units) above, outside the stated range (below it).
By their numbers in this assay, from the lowest: compounds 3 and 1 (each within the scatter of the next); then compound 2.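

In this assay, for the compounds shown here, this is the first single-place step: methyl(phenyl)amino in place of 4-carboxy-2-methoxyphenoxy gives a 40-fold lower number from compound 2 to compound 3 (1.60 log units; beyond the scatter), with the rest of the molecule unchanged. The group on this saturated chain carbon, three bonds along the chain from an amine nitrogen in a ring, can therefore shift the read-out well beyond the scatter, and 4-carboxy-2-methoxyphenoxy is not required for a low number. Nothing measured here explains the size of the step.

The exchange alters several features at once, so the carboxylic acid, the methoxy group and the ether oxygen remain unseparated. Also open, from the compounds shown here alone, is how a plain phenoxy group, a methyl ester in place of the carboxylic acid, or a longer chain would read in this assay.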